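A few compounds are considered here, and "the series" means these few. Any claim that something is new, unique, unknown or untested is made for them only; others in the source may bear on it.

Measured so far:
compound 1 `Cc1cc(NC(=O)Nc2ccc(C(C)(C)C)cc2)c2ccccc2n1` gives 17000 nM
compound 2 `COc1ccc(NC(=O)Nc2cc(C)nc3ccccc23)cc1F` gives only a limit, > 25000 nM

These values come from an ADME assay on HepG2 cells (Homo sapiens) for cytotoxicity, with a stated time of 72 h; a lower number here means that less compound is needed, a higher number that more compound is needed for the effect. Going by the values given here, compound 1 holds the only true number here. Compound 2 sits at a limit of the assay rather than a number, (the limit of > 25000 nM in this assay, at which 1 of the 2 values shown sits). Among the compounds with values here, no step between two measured compounds is available, so any expectation rests on the structural change alone. Compound 3 `Cc1cc(NC(=O)Nc2ccc(C(N)=O)cc2)c2ccccc2n1` is not yet measured; it differs from compound 1 by carbamoyl in place of tert-butyl on an aromatic carbon. In this assay the step of a 1.8-fold higher number from compound 1 to compound 3 (0.25 log units; within the scatter) is expected, toward needing more compound, and possibly beyond the usual scatter. Compound 3 is therefore estimated at 30000 nM, between 12000 nM and 80000 nM, with a fair chance that only a limit is reported.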

Compound 3, half-maximal effective concentration: > 25000 nM
Compound 3: a limit, no number (the forecaster's own chance of this, stated with the estimate: 55%); the middle value lies beyond the limit too.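

In this assay, carbamoyl in place of tert-butyl on this aromatic carbon gives an at least 1.4-fold higher number from compound 1 to compound 3 (0.16 log units; that floor lies within the scatter). This is the only step shown at this position, and it sets a floor rather than a size, so the true change could be small or large. Compound 3 gives a limit and not a number: the limit of > 25000 nM in this assay, at which 2 of the 3 values shown sit.

Going by these compounds, it remains open how an amine or a carboxylic acid at this position would read in this assay. Also open, on these data alone, is whether any group here would need clearly less compound than compound 1.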